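A few compounds are considered here, and "the series" means these few. Any claim that something is new, unique, unknown or untested is made for them only; others in the source may bear on it.

Measured so far:
compound 1, `Cc1ccccc1-c1nn(-c2ccc(F)cc2F)cc1CNCCN1CCN(C)CC1` — > 20000 nM
compound 2, `CCOC(=O)Cn1cc(CNCCN2CCN(C)CC2)c(-c2ccccc2C)n1` — > 20000 nM

In an ADME assay on Huh-7 cells (Homo sapiens) for cytotoxicity (on this read-out lower numbers stand for higher toxicity in this test and higher numbers for lower toxicity in this test), compound 1 gives > 20000 nM, which is a limit of the test rather than a number. Compound 2 gives > 20000 nM in this assay, again a limit. Among the measured compounds shown here, the only measured step, a step that the two limits leave unreadable from compound 1 to compound 2, cannot be read in size or direction because the limit of > 20000 nM in this assay, at which 2 of the 2 values shown sit, holds both of its ends. For compound 1, then, no position within the measured range of the test is known; all that can be said is that it sits at the edge.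

The unmeasured compound 3, `Cc1ccccc1-c1nn(-c2ccc(F)cc2F)cc1CNCc1ccncc1`, differs from compound 1 in one place: pyridin-4-yl in place of (4-methylpiperazin-1-yl)methyl on a saturated chain carbon bound to an amine nitrogen. For the measured compounds named here, no measured step touches this part of the molecule, and the one step that is known tells nothing about size, so the data give no direction for this change. With compound 1 at the limit, compound 3 is expected to sit at that limit as well, which amounts to the step that the limit leaves unreadable from compound 1 to compound 3. The estimate for compound 3 is 30000 nM, with a range from 10000 nM to 100000 nM.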

Compound 3, half-maximal cytotoxic concentration: > 20000 nM
Compound 3: no number, only a limit; the forecaster's own chance of this, stated with the estimate: 75%; the middle value lies beyond the limit too.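

In this assay compound 3 gives > 20000 nM, which is a limit and not a number. No step can be read from compound 1 to compound 3, as both ends sit at the same edge of the test: the limit of > 20000 nM in this assay, at which 3 of the 3 values shown sit. The compounds shown leave open how far each lies beyond that limit, and which change in structure, if any, would bring a measurable value.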